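From Vinyl to Allyl on Compound 2

The compounds below may be only part of what the source reports. "The series", "measured", "known", "first", "only" and "open" are said of these compounds alone.

Measured in a functional assay on KB cells (Homo sapiens) for inhibition, with a stated time of 72 h; on this read-out higher numbers stand for weaker inhibition and lower numbers for stronger inhibition:
- Compound 1 `CC(=O)O[C@@]12CO[C@@H]1C[C@H](O)[C@@](C)(C(=O)[C@H](O)C1=C(C)C3C[C@@](O)([C@H](C)OC(=O)CCC/C=C/CCCCC(=O)N[C@@H](c4ccccc4)[C@@H](O)C(=O)O3)C1(C)C)C2`: 14000 nM
- Compound 2 `C=CCCCC(=O)N[C@@H](c1ccccc1)[C@@H](O)C(=O)OC1C[C@@](O)([C@H](C)OC(=O)CCCC=C)C(C)(C)C([C@@H](O)C(=O)[C@@]2(C)C[C@]3(OC(C)=O)CO[C@@H]3C[C@@H]2O)=C1C`: 10 nM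

Among the measured compounds shown here, of the two compounds measured so far, compound 2 holds the lower number, 10 nM, and so shows the stronger inhibition. Compound 1 stands at 14000 nM, and the gap between the two lies well beyond the scatter of this assay.

Compound 3 `C=CCCCCC(=O)N[C@@H](c1ccccc1)[C@@H](O)C(=O)OC1C[C@@](O)([C@H](C)OC(=O)CCCC=C)C(C)(C)C([C@@H](O)C(=O)[C@@]2(C)C[C@]3(OC(C)=O)CO[C@@H]3C[C@@H]2O)=C1C` has yet to be measured. It differs from compound 2 in one place: allyl in place of vinyl on a saturated chain carbon, three bonds along the chain from a carbonyl carbon. In words, it carries allyl in place of vinyl on a saturated chain carbon, three bonds along the chain from a carbonyl carbon.

For the measured compounds named here, no measured pair of compounds shows this change on its own, so the expectation is a judgement that starts from compound 2 at 10 nM. Only a small move toward a higher number is expected in this assay, quite possibly none beyond the scatter. The estimated change is a 1.5-fold higher number from compound 2 to compound 3 (0.18 log units; within the scatter). For compound 3 the expected value is 15 nM, with an estimated range from 5 nM to 60 nM.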

Compound 3, half-maximal inhibitory concentration: 650 nM
Beside the measured number, compound 3's estimate is 43-fold (1.64 log units) below it; the whole stated range lies below it.
By their numbers in this assay, from the lowest: compound 2; then compound 3; then compound 1.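

In this assay, the change of vinyl to allyl on a saturated chain carbon, three bonds along the chain from a carbonyl carbon, gives a 65-fold higher number from compound 2 to compound 3 (1.81 log units; beyond the scatter). This position is therefore sensitive to a small edit, since both groups are open chains with one double bond outside aromatic rings, no hydrogen-bond donors or acceptors and no net charge, and the loss is still well beyond the scatter. Among the compounds shown here, compound 1 differs from compound 2 in more than one place, so only this step isolates the position, and no measurement at hand accounts for the size of the step.

The compounds shown leave open how the read-out moves as this chain is extended further, with but-3-en-1-yl, pent-4-en-1-yl or hex-5-en-1-yl in place of allyl, and so whether the loss deepens, levels off or reverses. They also leave open whether the double bond matters at all, a question that a saturated propyl group at this place would address.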